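The compounds below may be only part of what the source reports. "The series", "measured", "known", "first", "only" and "open" are said of these compounds alone.

Measured so far: compound 1 `CCOC(=O)c1cnc(-c2cccs2)nc1NN1C(=O)C=C(C)C1=O` gives 20 nM in a functional assay on Jurkat cells for inhibition of nuclear factor NF-kappa-B complex (Homo sapiens) (on this read-out lower numbers stand for stronger inhibition and higher numbers for weaker inhibition), and compound 2 `CCOC(=O)c1cnc(-c2cccc([N+](=O)[O-])c2)nc1NN1C(=O)C=C(C)C1=O` gives 7000 nM.

For the measured compounds named here, compound 2 stands at the highest of the two numbers, its only neighbour being compound 1, separated by a 350-fold higher number from compound 1 to compound 2 (2.54 log units; beyond the scatter). Compound 3 `CCOC(=O)c1cnc(-c2ccsc2)nc1NN1C(=O)C=C(C)C1=O` differs from compound 2 by thiophen-3-yl in place of 3-nitrophenyl on an aromatic carbon. Going by the values given here, the one step that bears on this is a 350-fold higher number from compound 1 to compound 2 (2.54 log units; beyond the scatter), a large rise on going to the nitrophenyl group; the step to compound 3 reverses that change, though to the thiophen-3-yl isomer rather than the thiophen-2-yl of compound 1. A large fall in this assay is therefore expected, of about a 120-fold lower number from compound 2 to compound 3 (2.07 log units; beyond the scatter). Compound 3 is estimated at 60 nM, with a range from 15 nM to 400 nM.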

Compound 3, half-maximal inhibitory concentration: 100 nM
Estimate against measurement, compound 3: 1.7-fold (0.22 log units) below, and the stated range covers the measured number.
By their numbers in this assay, from the lowest: compound 1; then compound 3; then compound 2.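

At the position between two ring nitrogen atoms, thiophen-3-yl restores most of what 3-nitrophenyl lost, with a 70-fold lower number from compound 2 to compound 3 (1.85 log units; beyond the scatter). The two thiophene attachments are not equivalent here, though this is the smaller step, with a 5.0-fold higher number from compound 1 to compound 3 (0.70 log units; beyond the scatter). Nothing at hand accounts for either step.

The compounds shown leave open whether the loss in compound 2 follows the nitro group or the six-membered ring, which an unsubstituted phenyl would separate. From the compounds shown here alone, whether the sulfur matters also stays open, and a furan-2-yl would test this.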